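From Methoxyphenyl to Chlorophenyl at the Amine Carbon

A few compounds are considered here, and "the series" means these few. Any claim that something is new, unique, unknown or untested is made for them only; others in the source may bear on it.

Going by the values given here, compound 2 `COc1ccc(CN(C)CCCn2c(=O)oc3ccccc32)cc1` gives 83 nM in an assay on membranes from liver for displacement of a labelled ligand from Sigma non-opioid intracellular receptor 1 (Rattus norvegicus), read by scintillation counting (on this read-out higher numbers stand for weaker inhibition and lower numbers for stronger inhibition), the highest of the two numbers measured so far; its nearest neighbour, compound 1 `COc1ccc(CN(C)C(C)CCn2c(=O)oc3ccccc32)cc1`, gives 21 nM in this assay. Among the compounds with values here, the only measured step, a 4.0-fold higher number from compound 1 to compound 2 (0.60 log units; beyond the scatter), concerns hydrogen in place of methyl on a saturated chain carbon bound to an amine nitrogen and a saturated chain carbon. Compound 3 `CN(CCCn1c(=O)oc2ccccc21)Cc1cccc(Cl)c1` differs from compound 2 elsewhere: 3-chlorophenyl in place of 4-methoxyphenyl on a saturated chain carbon bound to an amine nitrogen. Within the data shown here, no measured step touches the aromatic ring on that chain carbon, so these numbers hold no precedent for the size or direction of this change. With nothing to point either way, the step is expected to stay within the scatter, as a 1.4-fold lower number from compound 2 to compound 3 (0.14 log units; within the scatter). Compound 3 is therefore estimated at 60 nM in this assay, with a range from 15 nM to 250 nM.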

Compound 3, inhibition constant: 3230 nM
For compound 3 the middle estimate is 54-fold (1.73 log units) below the measured one; measured number above the stated range.
By their numbers in this assay, from the lowest: compound 1; then compound 2; then compound 3.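

On the saturated chain carbon bound to an amine nitrogen, the aromatic ring turns out to matter greatly in this assay: 3-chlorophenyl in place of 4-methoxyphenyl gives a 39-fold higher number from compound 2 to compound 3 (1.59 log units; beyond the scatter), a large step. The earlier compounds showed only a modest step, at the chain methyl, so this ring has the greater effect on the number among the changes shown. No measurement shown here bears on the reason for this rise.

This single change alters both the ring's substituent and where it sits, so the compounds shown leave open which of the two drives the step; 4-chlorophenyl and 3-methoxyphenyl would separate them. Also open, as far as these compounds go, is whether the chain methyl of compound 1 would lower the number with 3-chlorophenyl in place.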